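This account rests on a few compounds, and the source may have more. Where it says the series, first, only, none or still open, it means among the compounds named here.

Measured in an ADME assay on NIH3T3 cells (Mus musculus) for cytotoxicity; a lower number here means that less compound is needed, a higher number that more compound is needed for the effect:
- compound 1 `COc1cccc(Nc2cccc(Cn3ccnc3)c2)c1`: > 100000 nM
- compound 2 `Cc1cc(Oc2cccc(Cn3cccn3)c2)cc(C)c1Cl`: > 100000 nM

Neither entry is a number, so the series has no graded reading so far. Compound 2 gives > 100000 nM, which is a limit of the assay. Compound 1 gives > 100000 nM, which is also a limit. For the measured compounds named here, the position of compound 2 is therefore shared with the only other measured compound: the limit of > 100000 nM in this assay, at which 2 of the 2 values shown sit. Going by the values given here, no measured step connects the two compounds.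

Compound 3 `Cc1nnc(-c2cccc(Oc3cc(C)c(Cl)c(C)c3)c2)s1` is the next to be read. In compound 3, 5-methyl-1,3,4-thiadiazol-2-yl stands in place of (1H-pyrazol-1-yl)methyl on an aromatic carbon of a six-membered aromatic ring of carbon only, meta to a large group (5-methyl-1,3,4-thiadiazol-2-yl in place of (1H-pyrazol-1-yl)methyl on an aromatic carbon).

No change beyond the usual scatter is expected in this assay, and a reading reported again only as a limit is the likeliest outcome. This expectation rests on compound 2 and its limit, > 100000 nM. The expected step is a number no higher from compound 2 to compound 3 (the limit leaves the size open). For compound 3 the estimate is 100000 nM, with an expected range from 30000 nM to 150000 nM.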

Compound 3, half-maximal effective concentration: > 100000 nM
Compound 3: only a limit was reported; the forecaster's own chance of this, stated with the estimate: 75%; the middle value lies on the limit itself.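

No step can be read from compound 2 to compound 3, because both are reported only as limits in this assay, and the series sits at one shared limit: the limit of > 100000 nM in this assay, at which 3 of the 3 values shown sit.

The compounds shown leave open whether any structure in this series gives a graded reading in this assay, and how compound 1, compound 2 and compound 3 compare.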